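The compounds below may be only part of what the source reports. "The series", "measured", "known", "first", "only" and "open" are said of these compounds alone.

Measured so far in a functional assay on Ehrlich cells (Mus musculus) for cytotoxicity, read by trypan blue exclusion, with a stated time of 2 h; on this read-out lower numbers stand for stronger inhibition and higher numbers for weaker inhibition:

Compound 1 `N#CC1=C(N)N(c2ccc(S(N)(=O)=O)cc2)C2=C(CCCC2)C1c1ccc([N+](=O)[O-])cc1` gives > 100 ug/mL, a limit of the assay and not a number.
Compound 2 `N#CC1=C(N)N(c2ccc(S(N)(=O)=O)cc2)C2=C(CCCC2)C1c1ccccc1Cl` gives > 100 ug/mL, again a limit.
Compound 3 `COc1ccc(C2C(C#N)=C(N)N(c3ccc(S(N)(=O)=O)cc3)C3=C2CCCC3)c2ccccc12` gives > 100 ug/mL, also a limit.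

Compound 2 thus stands only at a limit, as the limit of > 100 ug/mL in this assay, at which 3 of the 3 values shown sit, records for every value shown. Among the compounds with values here, the one step that leads to it, a step that the two limits leave unreadable from compound 1 to compound 2, is unreadable, and compounds 2 and 3 both show nothing but limits. Compound 4 `Cc1ccc(C2C(C#N)=C(N)N(c3ccc(S(N)(=O)=O)cc3)C3=C2CCCC3)o1` differs from compound 2 by 5-methylfuran-2-yl in place of 2-chlorophenyl on a saturated ring carbon. Within the data shown here, no measured step offers a readable size to carry over, so the expected step that the limit leaves unreadable from compound 2 to compound 4 is none beyond the scatter. Compound 4 is therefore estimated at 150 ug/mL (range 50 ug/mL to 500 ug/mL), most probably reported again only as a limit in this assay.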

Compound 4, half-maximal inhibitory concentration: > 100 ug/mL
Compound 4 was reported as a limit; the forecaster's own chance of this, stated with the estimate: 80%; the middle value does not contradict the limit.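

The steps from compound 1 and from compound 2 to compound 4 cannot be read, with both ends of each step being limits: the limit of > 100 ug/mL in this assay, at which 4 of the 4 values shown sit.

The compounds shown leave open whether any group on the saturated ring carbon changes cytotoxicity at all.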